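The compounds below may be only part of what the source reports. "The series", "measured", "known", "first", "only" and "open" are said of these compounds alone.

In a functional assay on PC-3 cells (Homo sapiens) for cytotoxicity, read by MTT assay, with a stated time of 72 h (a lower number here means a stronger inhibitor, a higher number a weaker inhibitor), compound 1 `O=C(Nc1ccc(Oc2ccnc3[nH]ccc23)cc1)c1nn(-c2ccccc2)ccc1=O` gives 15000 nM. Compound 2 `O=C(Nc1ccc(Oc2ccnc3[nH]ccc23)cc1)c1nn(-c2ccc(Br)cc2F)ccc1=O` carries 4-bromo-2-fluorophenyl in place of phenyl on an aromatic nitrogen. In this assay compound 2 gives 12800 nM, and the step of a 1.2-fold lower number from compound 1 to compound 2 (0.07 log units; within the scatter) is therefore small.

Compound 3 `Cn1ccc2c(Oc3ccc(NC(=O)c4nn(-c5ccccc5)ccc4=O)cc3F)ccnc21` rests on a different core; the difference between its core and that of compound 1 is not broken down here. In this assay compound 3 gives > 60000 nM, which is a limit of the measurement and not a number. This is the limit described by the limit of > 60000 nM in this assay, at which 1 of the 3 values shown sits.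

Compound 4 `Cn1ccc2c(Oc3ccc(NC(=O)c4nn(-c5ccc(Br)cc5F)ccc4=O)cc3F)ccnc21` has not yet been measured in this assay. It stands to compound 3 as compound 2 stands to compound 1, with 4-bromo-2-fluorophenyl in place of phenyl on an aromatic nitrogen; the surroundings of the change are the same in both pairs, so it is the same change. Since the measured step of a 1.2-fold lower number from compound 1 to compound 2 (0.07 log units; within the scatter) lay within the scatter, the expected step that the limit leaves unreadable from compound 3 to compound 4 is likewise small. Compound 4 is thus expected to give about 80000 nM. For compound 4 the expected range runs from 30000 nM to 200000 nM, and a bare limit is the most likely outcome.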

Compound 4, half-maximal inhibitory concentration: 16300 nM
The estimate for compound 4 lay 4.9-fold (0.69 log units) above the measured number; the measured number lies below the stated range.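

In this assay, the change to 4-bromo-2-fluorophenyl in place of phenyl on the aromatic nitrogen did not carry over from one core to the other with the same size: the same change on two cores in this assay, a 1.2-fold lower number (0.07 log units; within the scatter) from compound 1 to compound 2 and an at least 3.6-fold lower number (0.56 log units; beyond the scatter) from compound 3 to compound 4, at least 3.1-fold (0.49 log units) apart, beyond the scatter of two such steps On the core of compound 3, the change gives an at least 3.6-fold lower number from compound 3 to compound 4 (0.56 log units; beyond the scatter), so a step that stayed within the scatter on the core of compound 1 cannot be assumed to stay small on another core in this series. Compound 3 gives > 60000 nM, which is a limit and not a number, so this shows only a lower bound on the step and not its true size: the limit of > 60000 nM in this assay, at which 1 of the 4 values shown sits.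

The compounds shown leave open whether the bromine or the fluorine alone accounts for the step on the core of compound 3, and how another group in that place, such as a methoxy group or an amine, would behave. They also leave open which part of the difference between the two cores goes with the gap between the two steps.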